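A few compounds are considered here, and "the series" means these few. Any claim that something is new, unique, unknown or untested is made for them only; others in the source may bear on it.

In a functional assay on A549 cells (Homo sapiens) for cytotoxicity, read by MTT assay, with a stated time of 72 h (on this read-out lower numbers stand for stronger inhibition and higher numbers for weaker inhibition), three compounds sharing one core have been measured. Compound 1 (`COc1cccc(/C=C2\CCC/C(=C\c3ccc(Cl)cc3)C2=O)c1OC`) gives > 20000 nM, a limit of the assay and not a number. Compound 2 (`COc1cccc(/C=C2\CCC/C(=C\c3ccc(Cl)cc3Cl)C2=O)c1OC`) gives > 20000 nM, also a limit. Among the measured compounds shown here, compound 3 (`COc1cccc(/C=C2\CCC/C(=C\c3cc(Cl)cc(Cl)c3)C2=O)c1OC`) gives 12500 nM, the only true number of the three. Compound 4 (`COc1cc(/C=C2\CCC/C(=C\c3cccc(OC)c3OC)C2=O)ccc1O`) has 4-hydroxy-3-methoxyphenyl in place of 3,5-dichlorophenyl on a double-bonded chain carbon bound to a double-bonded ring carbon. The steps bearing on this site are a step that the two limits leave unreadable from compound 1 to compound 2, an at least 1.6-fold lower number from compound 1 to compound 3 (0.20 log units; that floor lies within the scatter) and an at least 1.6-fold lower number from compound 2 to compound 3 (0.20 log units; that floor lies within the scatter). All of them exchange only chlorinated phenyl groups, so they set no size for this change. The expectation therefore starts from compound 3 at 12500 nM. No step beyond the scatter is expected. The expected step is a 1.0-fold lower number from compound 3 to compound 4 (0.02 log units; within the scatter). For compound 4 the estimate is 12000 nM, with an expected range of 4500 nM to 30000 nM.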

Compound 4, half-maximal inhibitory concentration: > 20000 nM
Compound 4 gave a limit, no number; the forecaster's own chance of this, stated with the estimate: 30%; middle value at least 1.6-fold (0.22 log units) away from the limit.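

In this assay compound 4 gives > 20000 nM, which is a limit and not a number. Placing 4-hydroxy-3-methoxyphenyl at this position, the first group here without chlorine, gives an at least 1.6-fold higher number from compound 3 to compound 4 (0.20 log units; that floor lies within the scatter), so this change brings no lower number, although that floor lies within the scatter. The steps from compound 1 and from compound 2 to compound 4 cannot be read, because all three compounds sit at the same limit: the limit of > 20000 nM in this assay, at which 3 of the 4 values shown sit.

Going by these compounds, how large the step to compound 4 truly is remains open. So does whether a phenyl group carrying an amine or a carboxylic acid at this position would move the read-out in either direction.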